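The source may report more compounds than this note shows. Statements on the series, on what has been measured and on what is new or still open speak of the compounds shown alone.

Measured so far, all in an ADME assay on MT4 cells (Homo sapiens) for cytotoxicity, read by MTT assay, with a stated time of 4 days; on this read-out lower numbers stand for higher toxicity in this test and higher numbers for lower toxicity in this test:

Compound 1 `CCOC(=O)c1cnc(N2CCN(Cc3ccc(C#N)cc3)CC2)nc1Oc1c(C)cc(-c2ccc(C#N)cc2)cc1C` gives > 125000 nM, which is a limit of the test rather than a number.
Compound 2 `CCOC(=O)c1cnc(N2CCN(Cc3cccc(C#N)c3)CC2)nc1Oc1c(C)cc(-c2ccc(C#N)cc2)cc1C` gives > 125000 nM, also a limit.
Compound 3 `CCOC(=O)c1cnc(N2CCN(Cc3cccc(C(F)(F)F)c3)CC2)nc1Oc1c(C)cc(-c2ccc(C#N)cc2)cc1C` gives > 125000 nM, again a limit.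

Compound 3 therefore stands where every measured compound here stands: at the limit of > 125000 nM in this assay, at which 3 of the 3 values shown sit. For the measured compounds named here, no compound in this set has produced a readable number, and so no step between them can be sized. The step that the two limits leave unreadable from compound 1 to compound 2 is unreadable, as is a step that the two limits leave unreadable from compound 1 to compound 3 and a step that the two limits leave unreadable from compound 2 to compound 3; each exchanges one group on the ring attached to the saturated chain carbon bound to an amine nitrogen in a ring, and each leaves the read-out at the limit.

Compound 4 `CCOC(=O)c1cnc(N2CCN(Cc3cccc([N+](=O)[O-])c3)CC2)nc1Oc1c(C)cc(-c2ccc(C#N)cc2)cc1C` continues this series of exchanges on the same ring: nitro in place of trifluoromethyl on an aromatic carbon. The three known steps bear on it only in that they show three different groups at comparable places, all without a measurable toxicity. Nothing in the data suggests a step in either direction beyond the scatter, and the most likely outcome is that compound 4 also reaches the limit. Compound 4 is therefore expected to give about 150000 nM, within 60000 nM to 400000 nM. That estimate corresponds to an expected step that the limit leaves unreadable from compound 3 to compound 4, essentially no change.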

Compound 4, half-maximal cytotoxic concentration: > 125000 nM
Compound 4 ended at the assay's limit (the forecaster's own chance of this, stated with the estimate: 85%); the middle value lies beyond the limit too.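

Compound 4 gives > 125000 nM, a limit rather than a number, so no step from compound 1, compound 2 or compound 3 to compound 4 can be read, and all four compounds sit together: the limit of > 125000 nM in this assay, at which 4 of the 4 values shown sit.

Left open is at what concentration each of the four compounds would harm the cells in this assay, and whether exchanging nitro, trifluoromethyl and cyano makes any difference there.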